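The source may report more compounds than this note shows. Statements on the series, on what has been measured and on what is new or still open speak of the compounds shown alone.

Compound 1 `COC(=O)N[C@H](C(=O)NN(CCC[C@@](O)(Cc1ccccc1)C(=O)N[C@H]1c2ccccc2C[C@H]1O)Cc1ccc(F)cc1)C(C)(C)C` gives > 10000 nM in an ADME assay on MT4 cells (Homo sapiens) for cytotoxicity; on this read-out lower numbers stand for higher toxicity in this test and higher numbers for lower toxicity in this test.
Compound 2 `COC(=O)N[C@H](C(=O)NN(CCC[C@@](O)(Cc1ccccc1)C(=O)N[C@H]1c2ccccc2C[C@H]1O)Cc1ccc(-c2cncnc2)cc1)C(C)(C)C` gives > 10000 nM in this assay.
Compound 3 `COC(=O)N[C@H](C(=O)NN(CCC[C@@](O)(Cc1ccccc1)C(=O)N[C@H]1c2ccccc2C[C@H]1O)Cc1ccc(-c2nc(C(C)(C)C)cs2)cc1)C(C)(C)C` gives > 10000 nM in this assay.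

For compound 1 the result in this assay is a limit of the assay, not a number. The two other values shown are limits too, so that the limit of > 10000 nM in this assay, at which 3 of the 3 values shown sit, describes all three compounds. Compound 4 `COC(=O)N[C@H](C(=O)NN(CCC[C@@](O)(Cc1ccccc1)C(=O)N[C@H]1c2ccccc2C[C@H]1O)Cc1ccc(-c2ccsc2)cc1)C(C)(C)C` differs from compound 1 by thiophen-3-yl in place of fluoro on an aromatic carbon. Going by the values given here, the steps that bear on this change, a step that the two limits leave unreadable from compound 1 to compound 2 and a step that the two limits leave unreadable from compound 1 to compound 3, both replace the same fluoro by an aromatic ring, and neither can be read. Among the compounds with values here, no step in this assay is therefore expected beyond the scatter. Because the limit of > 10000 nM in this assay, at which 3 of the 3 values shown sit, holds for every compound shown, compound 4 is expected to sit at the same limit, with an estimate of 20000 nM between 8000 nM and 60000 nM, the expected step being a step that the limit leaves unreadable from compound 1 to compound 4.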

Compound 4, half-maximal cytotoxic concentration: > 10000 nM
Compound 4: no number, only a limit; the forecaster's own chance of this, stated with the estimate: 85%; the middle value is on the limit's open side.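

Going by these compounds alone, compound 4 gives only a limit in this assay and so no step among compound 1, compound 2, compound 3 and compound 4 can be read: the limit of > 10000 nM in this assay, at which 4 of the 4 values shown sit. The compounds shown leave open whether any aromatic ring in place of fluoro shifts the half-maximal cytotoxic concentration at all.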